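This account rests on a few compounds, and the source may have more. Where it says the series, first, only, none or still open, it means among the compounds named here.

Results in a functional assay on NCI-H1581 cells (Homo sapiens) for antiproliferative activity, read by CCK-8 assay, with a stated time of 72 h; on this read-out higher numbers stand for weaker inhibition and lower numbers for stronger inhibition:
- Compound 1 `COc1cc(OC)c(Cl)c(-c2ccc3c(NC(=O)c4ccc(N5CCN(C6CCC6)CC5)cc4)n[nH]c3n2)c1Cl`: 2.3 nM
- Compound 2 `COc1cc(OC)cc(-c2ccc3c(NC(=O)c4ccc(N5CCN(C)CC5)cc4)n[nH]c3n2)c1`: > 1000 nM
- Compound 3 `COc1cc(OC)c(Cl)c(-c2ccc3c(NC(=O)c4ccc(N5CCN(C)CC5)cc4)nn(C)c3n2)c1Cl`: "not determined" (no result reported)

For the measured compounds named here, compound 1, at 2.3 nM, holds the only exact number in this small set. Compound 2 gives > 1000 nM, which is a limit of the assay and not a number. Compound 3 has no usable result.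

Compound 4 `COc1cc(OC)c(Cl)c(-c2ccc3c(NC(=O)c4ccc(N)cc4)n[nH]c3n2)c1Cl` keeps the core of compound 1 and changes one group: amino in place of 4-cyclobutylpiperazin-1-yl on an aromatic carbon. This puts amino in place of 4-cyclobutylpiperazin-1-yl on an aromatic carbon. Going by the values given here, no measured pair isolates this change, and all three measured compounds carry a piperazine there, so the forecast is a judgement. Starting from compound 1 at 2.3 nM, a clear weakening beyond the usual scatter is expected in this assay, an estimated step of a 17-fold higher number from compound 1 to compound 4 (1.24 log units; beyond the scatter). The estimated value for compound 4 is 40 nM, with an expected range of 8 nM to 250 nM.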

Compound 4, half-maximal inhibitory concentration: 218 nM
Estimate against measurement, compound 4: 5.5-fold (0.74 log units) below, and the stated range covers the measured number.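

In this assay, for the compounds shown here, amino in place of 4-cyclobutylpiperazin-1-yl gives a 95-fold higher number from compound 1 to compound 4 (1.98 log units; beyond the scatter) as the first measured single change in this set, so the group at this position matters greatly. Even so, compound 4 still gives 218 nM with only amino there, which is a real number and not a limit of the assay. Nothing measured here explains the size of this step.

On these data alone, it remains open which part of the larger group counts. A morpholine ring or a dimethylamino group at this position could help separate the contribution of the ring from that of the cyclobutyl group.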